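Replacing phenyl with isopropyl in compound 3

The source may report more compounds than this note shows. Statements on the series, on what has been measured and on what is new or still open speak of the compounds shown alone.

Of the compounds shown here, three sharing one core have been measured in a functional assay on the whole organism for antagonist activity, with Mus musculus as the target; a lower number here means that less compound is needed, a higher number that more compound is needed for the effect. Compound 1 `CCCCCC(=O)NCC(=O)N(C)c1ccc(Cl)cc1C(=O)c1ccccc1Cl`, with pentyl on the carbonyl carbon, gives 1.9 mg/kg. Compound 3 `CN(C(=O)CNC(=O)c1ccccc1)c1ccc(Cl)cc1C(=O)c1ccccc1Cl`, with phenyl at that place, gives 2.9 mg/kg. Compound 2 `CN1CCN(CC(=O)NCC(=O)N(C)c2ccc(Cl)cc2C(=O)c2ccccc2Cl)CC1`, with (4-methylpiperazin-1-yl)methyl there, gives 59 mg/kg. Compound 3 therefore stands level with compound 1 and far from compound 2, the gap to the latter being a 20-fold lower number from compound 2 to compound 3 (1.31 log units; beyond the scatter).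

The next structure is compound 4 `CC(C)C(=O)NCC(=O)N(C)c1ccc(Cl)cc1C(=O)c1ccccc1Cl`, which carries isopropyl in place of phenyl on a carbonyl carbon. For the measured compounds named here, two measured steps bear on this change. The exchange of pentyl for phenyl gave a 1.5-fold higher number from compound 1 to compound 3 (0.18 log units; within the scatter), and isopropyl, like those two groups, is made of carbon only. The large change, a 31-fold higher number from compound 1 to compound 2 (1.49 log units; beyond the scatter), came with the 4-methylpiperazin-1-yl group, which does not enter here. This rests on very few compounds, and compound 2 is the only one that departs from the others. On these data alone, no step beyond the scatter is expected in this assay, and the direction remains open. The expected step is a 1.2-fold lower number from compound 3 to compound 4 (0.06 log units; within the scatter). For compound 4 the estimated value is 2.5 mg/kg, with an expected range from 1.1 mg/kg to 6 mg/kg.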

Compound 4, dose for half-maximal effect: 6 mg/kg
Estimate against measurement, compound 4: 2.4-fold (0.38 log units) below; measured number inside the range.
By their numbers in this assay, from the lowest: compounds 1 and 3 (each within the scatter of the next); then compound 4; then compound 2.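

In this assay, the position on the carbonyl carbon proves sensitive to a change among groups made of carbon only, which compound 1 and compound 3 alone had not shown: isopropyl in place of phenyl gives a 2.1-fold higher number from compound 3 to compound 4 (0.32 log units; beyond the scatter), and isopropyl in place of pentyl gives a 3.2-fold higher number from compound 1 to compound 4 (0.50 log units; beyond the scatter). Compound 4 still lies well apart from the compound bearing the amine, with isopropyl in place of (4-methylpiperazin-1-yl)methyl giving a 9.8-fold lower number from compound 2 to compound 4 (0.99 log units; beyond the scatter), so the three kinds of group now fall on three levels, with pentyl and phenyl sharing the lowest. Nothing available explains the difference between isopropyl and the two other carbon groups.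

The compounds shown cannot separate the effect of branching from that of chain length or ring, and an unbranched propyl, a cyclohexyl or a longer chain would bear on that question. On these data alone, it also remains open whether the large rise seen with compound 2 belongs to amines in general, which a dimethylamino group could test, or whether a carboxylic acid at this position would behave alike.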